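The source may report more compounds than this note shows. Statements on the series, on what has been measured and on what is new or still open speak of the compounds shown alone.

Compound 1, `CCOc1ccc(F)cc1C(C)NC(=O)N(C)S(=O)(=O)c1ccccc1`, gives 11500 nM in a functional assay on thoracic aorta (Rattus norvegicus, strain Wistar), with a stated time of 15 min; a lower number here means that less compound is needed, a higher number that more compound is needed for the effect. Compound 2, `CCOc1ccc(Cl)cc1C(C)NC(=O)N(C)S(=O)(=O)c1ccccc1`, gives 10500 nM in this assay, and the step of a 1.1-fold lower number from compound 1 to compound 2 (0.04 log units; within the scatter) leaves the two compounds side by side within the scatter, so compound 2 stands with compound 1 among the two numbers that are known. Compound 3, `CCOc1ccc(Cl)cc1C(C)NC(=O)NS(=O)(=O)c1ccccc1`, reaches only a limit of the assay in this assay, > 300000 nM, and so gives no number. The step of an at least 28-fold higher number from compound 2 to compound 3 (1.45 log units; beyond the scatter) is therefore a large one, reaching (the limit of > 300000 nM in this assay, at which 1 of the 3 values shown sits).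

Compound 4, `COc1ccc(Cl)cc1C(C)NC(=O)N(C)S(=O)(=O)c1ccccc1`, differs from compound 2 only in the ethoxy group: hydrogen in place of methyl on a saturated chain carbon bound to an oxygen on an aromatic ring. Neither measured step touches this part of the molecule. The step from compound 1 to compound 2 alters a halogen on an aromatic carbon, and the step from compound 2 to compound 3 removes the methyl from the amide-type nitrogen. Both steps leave the ethoxy group unchanged, so they give no direct guide to the shortening of ethyl to methyl. With no evidence pointing either way, a step of no more than the scatter is expected for a 1.1-fold higher number from compound 2 to compound 4 (0.06 log units; within the scatter). Compound 4 is therefore estimated at 12000 nM, with a range from 4000 nM to 36000 nM.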

Compound 4, half-maximal effective concentration: 7200 nM
Estimate against measurement, compound 4: 1.7-fold (0.22 log units) above, within the range that was stated.
By their numbers in this assay, from the lowest: compounds 4, 2 and 1 (each within the scatter of the next). At a limit, above all of these: compound 3.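

The earlier steps shown here changed the halogen and the amide-type nitrogen but left the ethoxy group untouched, and in this assay the step of a 1.5-fold lower number from compound 2 to compound 4 (0.16 log units; within the scatter) now shows that ethoxy can be shortened to methoxy without a change beyond the scatter. The same exchange of hydrogen for methyl therefore has very different outcomes at the two places tested: on the saturated chain carbon bound to an oxygen on an aromatic ring it stays within the scatter, whereas on the amide-type nitrogen the step of an at least 28-fold higher number from compound 2 to compound 3 (1.45 log units; beyond the scatter) reaches a limit of the assay. Nothing given here accounts for the small size of the step at the ethoxy group.

The compounds shown leave open whether a longer chain such as propoxy, a branched group such as isopropoxy, or a hydroxyl group in this place would also stay within the scatter of compound 2 and compound 4. Also open, going by these compounds, is whether ethoxy and methoxy would stand as close together with fluoro in place of chloro, as the change is seen here only with the chloro group.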